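Solubility in a Shared Core: Two Measured, One Expected

The source may hold more compounds than are shown below. What is called first, only, known or untested is meant among the compounds shown, and "the series" means these compounds.

Of the compounds shown here, two built on a shared core have been measured in a physicochemical assay for solubility, read by spectrophotometry, in phosphate buffer, with a stated time of 18 h, at pH 7.4; on this read-out higher numbers stand for higher solubility and lower numbers for lower solubility. Compound 1 `CCc1ccc(-c2nc3c(c(C)nn3-c3ccccc3)c(-c3ccccc3Cl)c2C#N)cc1` gives 1700 nM in this assay. Compound 2 `Cc1cccc(-c2nc3c(c(C)nn3-c3ccccc3)c(-c3ccccc3O)c2C#N)c1` gives 42000 nM in this assay, the highest of the two numbers; its nearest neighbour is compound 1, which lies well below it, a gap beyond the scatter of this kind of measurement.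

Compound 3 `Cc1nn(-c2ccccc2)c2nc(-c3ccc([N+](=O)[O-])cc3)c(C#N)c(-c3ccccc3O)c12` has not yet been measured in this assay. It differs from compound 2 in one place: 4-nitrophenyl in place of 3-methylphenyl on an aromatic carbon. For the measured compounds named here, no step between two measured compounds mirrors this change, so the expectation rests on compound 2 and on the change itself. A moderate move downward in this assay, somewhat beyond the scatter, is expected for the step of a 2.8-fold lower number from compound 2 to compound 3 (0.45 log units; beyond the scatter). Compound 3 is therefore estimated at 15000 nM in this assay, with a likely range from 4000 nM to 60000 nM.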

Compound 3, solubility: 6000 nM
For compound 3 the middle estimate is 2.5-fold (0.40 log units) above the measured one, within the range that was stated.
By their numbers in this assay, from the lowest: compound 1; then compound 3; then compound 2.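

This position, on an aromatic carbon next to the ring nitrogen and ortho to a cyano group, proves sensitive to what it carries: in this assay, 4-nitrophenyl in place of 3-methylphenyl gives a 7.0-fold lower number from compound 2 to compound 3 (0.85 log units; beyond the scatter), with the rest of the structure unchanged. For the compounds shown here, this is the first step between measured compounds that differ in one place, so one change can now be read on its own, which the gap between the two earlier compounds did not allow. No supporting data bear on why the number drops.

On these data alone, whether the step follows from the nitro group itself or from where it sits on the phenyl ring stays open with this single pair. As far as these compounds go, how an amine or a carboxylic acid on that phenyl ring would read in this assay also remains open.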